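Methoxy in Place of Chloro: What to Expect

The source may report more compounds than this note shows. Statements on the series, on what has been measured and on what is new or still open speak of the compounds shown alone.

Compound 2 `COc1cc(OC)c(OC)cc1/C=C/COC(=O)/C=C/c1ccc(Cl)cc1` is the point of departure. In a functional assay on the whole organism (strain Kunming) with Mus musculus as the target, with a stated time of 0.5 h, at a dose of 300 mg/kg by the intraperitoneal route (a lower number here means a stronger effect, a higher number a weaker effect of the compound at the dose given), compound 2 gives 100%. Compound 1 `COc1cc(OC)c(OC)cc1/C=C/COC(=O)/C=C/c1c(OC)ccc(OC)c1OC` gives 100% in this assay, and compound 3 `COc1cc(OC)c(OC)cc1/C=C/COC(=O)/C=C/c1cc(OC)c(OC)c(OC)c1OC` gives 100% there; compound 2 thus stands level with both at the digits given, within the scatter of the method, and no order among the three can be drawn. The compound not yet measured is compound 4 `COc1ccc(/C=C/C(=O)OC/C=C/c2cc(OC)c(OC)cc2OC)cc1`. From compound 2 it differs in one place: methoxy in place of chloro on an aromatic carbon. The change sits on an aromatic carbon of a six-membered aromatic ring of carbon only, para to a large group; the chloro leaves and the methoxy enters. Within the data shown here, no step between measured compounds is available to size this substitution directly. The three measured compounds, whether carrying chloro or several methoxy groups on that ring, all sit at one level, so compound 4 is expected to show no step beyond the scatter, no change at the digits printed from compound 2 to compound 4 (within the scatter). Compound 4 is therefore estimated at 100%, within 85% to 100%.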

Compound 4, a percentage reported as activity, at one dose (the size of the read-out at that dose, not a potency): 100%
The estimate for compound 4 equals the measured number at the digits printed, within the range that was stated.
By their numbers in this assay, from the lowest: compounds 1, 2, 3 and 4 (each within the scatter of the next).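

In this assay, among these compounds, the exchange of chloro for methoxy on an aromatic carbon, para to a large group, gives the first step that can be read at this position (no change at the digits printed from compound 2 to compound 4 (within the scatter)). Among the compounds shown here, none of the earlier compounds formed a pair differing in one place, so the level they shared could not be tied to any single group. This pair ties it to one exchange: at this single dose, the read-out does not separate 4-chlorophenyl from 4-methoxyphenyl. Nothing at hand accounts for this result.

On these data alone, whether an amine, a carboxylic acid or a longer chain such as butoxy at this position would shift the read-out remains open. Also open, as far as these compounds go, is whether chloro and methoxy would separate at a different dose, as one dose gives the size of the effect and not a potency.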